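Ester-to-ether swap at the chain end, compound 3

The source may hold more compounds than are shown below. What is called first, only, known or untested is meant among the compounds shown, and "the series" means these compounds.

Compound 1 `COC(=O)/C=C/c1cccc(N(Cc2ccc(/C=C/c3cccc(F)c3)cc2)C(=O)C2CCCCC2)c1` carries a 3-fluorophenyl on a double-bonded chain carbon bound to a double-bonded chain carbon; in an assay on isolated protein with Bile acid receptor (Homo sapiens) as the target (on this read-out lower numbers stand for an effect already at smaller amounts and higher numbers for an effect only at larger amounts of compound), compound 1 gives 86 nM. Compound 2 `COC(=O)/C=C/c1cccc(N(Cc2ccc(/C=C/C(=O)OCc3ccccc3)cc2)C(=O)C2CCCCC2)c1` has benzyloxycarbonyl at that place. In this assay compound 2 gives only a limit of the assay, > 1000 nM. The step of an at least 11-fold higher number from compound 1 to compound 2 (1.06 log units; beyond the scatter) is therefore known only as a lower bound, resting on (the limit of > 1000 nM in this assay, at which 1 of the 2 values shown sits). Compound 3 `COC/C=C/c1ccc(CN(C(=O)C2CCCCC2)c2cccc(/C=C/C(=O)OC)c2)cc1` is the next member: methoxymethyl in place of benzyloxycarbonyl on a double-bonded chain carbon bound to a double-bonded chain carbon. Within the data shown here, only the step from compound 1 to compound 2 bears on this change, and it shows that benzyloxycarbonyl at this place costs potency relative to 3-fluorophenyl; whether methoxymethyl at the same place recovers any of that loss cannot be read from the two measured compounds, so no direction for compound 3 in this assay is established. Compound 3 is expected to remain at the weak end, with an estimate of 1500 nM (range 300 nM to 8000 nM). This expected value corresponds to a step that the limit leaves unreadable from compound 2 to compound 3 and is an estimate, not a measurement.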

Compound 3, half-maximal effective concentration: 233 nM
For compound 3 the middle estimate is 6.4-fold (0.81 log units) above the measured one, and the stated range ends above it.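

In this assay, methoxymethyl in place of benzyloxycarbonyl on a double-bonded chain carbon bound to a double-bonded chain carbon gives an at least 4.2-fold lower number from compound 2 to compound 3 (0.63 log units; beyond the scatter), so a group with no ring can hold a measurable value at this place and the loss seen with benzyloxycarbonyl does not extend to every replacement of 3-fluorophenyl. Set against 3-fluorophenyl, the same group gives a 2.7-fold higher number from compound 1 to compound 3 (0.43 log units; beyond the scatter), so methoxymethyl recovers part of that loss but not all of it, and a ring at this place is not a requirement for a value in this range. Compound 2 sits at a limit of the assay, so the first of these steps is a lower bound only: the limit of > 1000 nM in this assay, at which 1 of the 3 values shown sits.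

The three groups differ at once in size, ring content and acceptor count, so these compounds do not separate which of these features sets the order. On these data alone, how a plain phenyl, a hydroxymethyl or an aminomethyl at the same place would read in this assay stays open.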